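A Fluorine on the Benzyl Ring of an HDAC6 Inhibitor

The source may report more compounds than this note shows. Statements on the series, on what has been measured and on what is new or still open speak of the compounds shown alone.

Of the compounds shown here, two sharing one core have been measured in an assay on isolated protein for inhibition of protein deacetylase HDAC6 (Homo sapiens), with a stated time of 60 min; a higher number here means a weaker inhibitor, a lower number a stronger inhibitor. Compound 1 `O=C(CCCCCn1cc(Nc2ncc3ccn(Cc4ccccc4)c3n2)cn1)NO` gives 13.8 nM. Compound 2 `O=C(CCCCCCn1cc(Nc2ncc3ccn(Cc4ccccc4)c3n2)cn1)NO`, which carries (hydroxycarbamoyl)methyl in place of hydroxycarbamoyl at the end of the chain, gives 12.5 nM. The step of a 1.1-fold lower number from compound 1 to compound 2 (0.04 log units; within the scatter) shows that the longer chain barely shifts the number. Among the measured compounds shown here, compound 2 therefore gives the lowest of the two numbers, yet its only neighbour, compound 1, lies within the scatter of it, so the two cannot be told apart.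

Compound 3 `O=C(CCCCCCn1cc(Nc2ncc3ccn(Cc4cccc(F)c4)c3n2)cn1)NO` keeps the chain of compound 2 and changes only the benzyl ring: fluoro in place of hydrogen on an aromatic carbon. For the measured compounds named here, no measured step touches this ring; the single step from compound 1 to compound 2 concerns the chain alone, so it says nothing about how a fluoro substituent on the aromatic ring will act. Going by the values given here, with no direct precedent, the expectation is a step of about a 1.1-fold lower number from compound 2 to compound 3 (0.06 log units; within the scatter), that is, no change beyond the scatter. Compound 3 is therefore estimated at 11 nM, with a likely range from 5 nM to 25 nM.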

Compound 3, half-maximal inhibitory concentration: 14.7 nM
For compound 3 the middle estimate is 1.3-fold (0.13 log units) below the measured one; the range from low to high includes it.
By their numbers in this assay, from the lowest: compounds 2, 1 and 3 (each within the scatter of the next).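

In this assay, the change from benzyl to 3-fluorobenzyl gives a 1.2-fold higher number from compound 2 to compound 3 (0.07 log units; within the scatter), so compound 2 and compound 3 cannot be told apart. Among the compounds shown here, this is the first reading on the benzyl ring, which the chain step could not provide: a single fluoro on this aromatic carbon, meta to a large group, is tolerated here without a shift beyond the scatter, and the same is true of the chain step, a 1.1-fold lower number from compound 1 to compound 2 (0.04 log units; within the scatter). No measurement is available that would explain this result.

From the compounds shown here alone, one small atom at one ring position is a narrow test, so it remains open whether a larger or different group on the same carbon, such as chloro, methoxy, an amine or a carboxylic acid, would also stay within the scatter or would give a clear step. Going by these compounds, it is also open whether fluoro on another carbon of the ring would match compound 3, and whether a longer chain than that of compound 2 would continue to give a number within the scatter.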